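The compounds below may be only part of what the source reports. "The series", "measured", "known", "first", "only" and "open" are said of these compounds alone.

Measured compounds in a functional assay on SNB-19 cells (Homo sapiens) for inhibition, read by sulforhodamine B assay, with a stated time of 48 h, tested at 10 uM; a higher number here means more inhibition at the concentration tested (going by the name of the read-out), a lower number less inhibition:
- Compound 1 `Brc1cn2ccnc2c(-c2ccc3ncn(C4CCCCC4)c3c2)n1` gives 8.09%.
- Compound 2 `c1cn2cc(-c3ccsc3)nc(-c3ccc4ncn(C5CCCCC5)c4c3)c2n1` gives 0.39%.
- Compound 3 `Brc1ccc(-c2cn3ccnc3c(-c3ccc4ncn(C5CCCCC5)c4c3)n2)cc1` gives 18.3%.

Among these three, compound 1 stands second highest. Compound 2 is its nearest neighbour, and the step of a number 7.7 percentage points lower from compound 1 to compound 2 (within the scatter) lies within the scatter, so the two cannot be told apart. Compound 3 is furthest away, and the step of a number 10.2 percentage points higher from compound 1 to compound 3 (beyond the scatter) is beyond the scatter, though modest.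

Compound 4 `Fc1ccccc1-c1cn2ccnc2c(-c2ccc3ncn(C4CCCCC4)c3c2)n1` has not yet been measured. It differs from compound 1 in one place: 2-fluorophenyl in place of bromo on an aromatic carbon. Within the data shown here, the step that bears most on this is the one from compound 1 to compound 3, where a six-membered aromatic carbon ring also entered in place of bromo and the number rose by a number 10.2 percentage points higher from compound 1 to compound 3 (beyond the scatter). The step of a number 7.7 percentage points lower from compound 1 to compound 2 (within the scatter), where a different ring entered, shows no change beyond the scatter. A modest rise is therefore expected, and for compound 4 the estimate in this assay is 15%, with a range from 2% to 30%, corresponding to an expected step of a number 6.9 percentage points higher from compound 1 to compound 4 (within the scatter).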

Compound 4, a percentage reported as inhibition, at one concentration (the size of the read-out at that concentration, not a potency): 7.56%
Compound 4: the middle estimate sits 7.4 percentage points above what was measured; measured number inside the range.
By their numbers in this assay, from the lowest: compounds 2, 4 and 1 (each within the scatter of the next); then compound 3.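

In this assay, the step of a number 0.5 percentage points lower from compound 1 to compound 4 (within the scatter) shows that a six-membered aromatic carbon ring on this carbon does not in itself separate a compound from the bromo compound, so the rise seen with 4-bromophenyl is not shared by every substituted phenyl group. The two phenyl groups can be told apart, with a number 10.7 percentage points lower from compound 3 to compound 4 (beyond the scatter) as the step, while the step of a number 7.2 percentage points higher from compound 2 to compound 4 (within the scatter) leaves 2-fluorophenyl and thiophen-3-yl indistinguishable, and so only compound 3 stands apart from the others in this set. No measurement is available that would explain these differences. Going by these compounds, the two phenyl groups differ in both their halogen and its place on the ring, so it remains open which of these matters. Also open, on these data alone, is how plain phenyl, or a phenyl ring carrying an amine or a carboxylic acid, would behave on this carbon.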